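The source may hold more compounds than are shown below. What is called first, only, known or untested is meant among the compounds shown, and "the series" means these compounds.

Two compounds define the starting ground. Compound 1 `CN1CCC(n2cc(S(=O)(=O)c3cccc4ccccc34)c3ccccc32)C1` gives 6 nM in an assay on HeLa cells for displacement of a labelled ligand from 5-hydroxytryptamine receptor 6 (Homo sapiens), with a stated time of 2 h (a lower number here means a stronger inhibitor, a higher number a weaker inhibitor), and compound 2 `O=S(=O)(c1cccc(F)c1)c1cn(C2CCCNC2)c2ccc(F)cc12` gives 4 nM in this assay; the two values lie within the scatter of each other, so neither can be set apart from the other. Compound 3 `CN1CCCC(n2cc(S(=O)(=O)c3cccc4ccccc34)c3ccccc32)C1` is the unmeasured neighbour of compound 1, differing in one place: 1-methylpiperidin-3-yl in place of 1-methylpyrrolidin-3-yl on an aromatic nitrogen. Among the measured compounds shown here, no comparable measured pair exists, so the step from compound 1 to compound 3 is estimated as a 1.3-fold higher number from compound 1 to compound 3 (0.12 log units; within the scatter) in this assay, with nothing beyond the scatter expected. Compound 3 is therefore expected to give about 8 nM in this assay, likely between 3 nM and 25 nM.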

Compound 3, inhibition constant: 7.1 nM
For compound 3 the middle estimate is 1.1-fold (0.05 log units) above the measured one, and the stated range covers the measured number.
By their numbers in this assay, from the lowest: compounds 2, 1 and 3 (each within the scatter of the next).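

In this assay the step is a 1.2-fold higher number from compound 1 to compound 3 (0.07 log units; within the scatter), with 1-methylpiperidin-3-yl in place of 1-methylpyrrolidin-3-yl on the aromatic nitrogen. On the core of compound 1, this position therefore takes the six-membered ring as well as the five-membered one, with no difference that can be read. Nothing available bears on why the two rings read alike. From the compounds shown here alone, it remains open whether a 1-ethylpiperidin-3-yl group or an open-chain amine such as 2-(dimethylamino)ethyl would also hold the number at this position.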